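The source may report more compounds than this note shows. Statements on the series, on what has been measured and on what is new or still open speak of the compounds shown alone.

Three compounds share one core and differ only in the group on a single aromatic carbon. Compound 1 `CCC(C)c1cc(C)c(C(=O)N=C(N)N)cc1S(C)(=O)=O` gives 8 nM in a functional assay for inhibition of sodium/hydrogen exchanger (Oryctolagus cuniculus); a lower number here means a stronger inhibitor, a higher number a weaker inhibitor. Compound 2 `Cc1cc(C2CCC2)c(S(C)(=O)=O)cc1C(=O)N=C(N)N` gives 8.2 nM in this assay, and compound 3 `Cc1cc(Sc2ccccc2)c(S(C)(=O)=O)cc1C(=O)N=C(N)N` gives 14 nM in this assay. Compound 3 has the highest of the three numbers, yet its steps to compound 2 and to compound 1 both lie within the scatter. Compound 4 `Cc1cc(N2CCCC2)c(S(C)(=O)=O)cc1C(=O)N=C(N)N` differs from compound 3 by pyrrolidin-1-yl in place of phenylsulfanyl on an aromatic carbon. For the measured compounds named here, the steps that bear on this place are a 1.8-fold higher number from compound 1 to compound 3 (0.24 log units; within the scatter) and a 1.7-fold higher number from compound 2 to compound 3 (0.23 log units; within the scatter), and a 1.0-fold higher number from compound 1 to compound 2 (0.01 log units; within the scatter) is likewise within the scatter. Swapping the group at this carbon has so far not moved the number beyond the scatter, so no step beyond the scatter is expected in this assay. Compound 4 is expected to give 11 nM, between 4 nM and 30 nM, a step of a 1.3-fold lower number from compound 3 to compound 4 (0.10 log units; within the scatter).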

Compound 4, half-maximal inhibitory concentration: 11 nM
The estimate for compound 4 equals the measured number at the digits printed; low and high end bracket the measured number.
By their numbers in this assay, from the lowest: compounds 1, 2, 4 and 3 (each within the scatter of the next).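

With pyrrolidin-1-yl, a ring joined through nitrogen now sits on the aromatic carbon ortho to a methylsulfonyl group, and in this assay the steps of a 1.3-fold lower number from compound 3 to compound 4 (0.10 log units; within the scatter) and a 1.3-fold higher number from compound 2 to compound 4 (0.13 log units; within the scatter) and a 1.4-fold higher number from compound 1 to compound 4 (0.14 log units; within the scatter) all lie within the scatter. Groups joined through carbon, sulfur and nitrogen have therefore all been placed here without a step beyond the scatter. No measured evidence accounts for this result. Still open, going by these compounds, is whether a carboxylic acid, a primary amine or a longer chain on this carbon would give a step beyond the scatter.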